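The source may report more compounds than this note shows. Statements on the series, on what has been measured and on what is new or still open speak of the compounds shown alone.

Compound 2 `COc1cccc(/C=C2\CCC/C(=C\c3ccc([N+](=O)[O-])cc3)C2=O)c1` gives 51.4 ug/mL in a functional assay on MDA-MB-231 cells (Homo sapiens) for cytotoxicity, read by MTT assay (a higher number here means a weaker inhibitor, a lower number a stronger inhibitor), the highest of the three numbers measured. Compound 1 `COc1ccc(/C=C2\CCC/C(=C\c3cccc([N+](=O)[O-])c3)C2=O)cc1` gives 44.7 ug/mL, within the scatter of compound 2. Compound 3 `COc1cccc(/C=C2\CCC/C(=C\c3ccc([N+](=O)[O-])cc3)C2=O)c1OC` gives 6.73 ug/mL. For the measured compounds named here, the one step beyond the scatter is a 7.6-fold lower number from compound 2 to compound 3 (0.88 log units; beyond the scatter). Compound 4 `COc1cc(/C=C2\CCC/C(=C\c3ccc([N+](=O)[O-])cc3)C2=O)ccc1O` differs from compound 2 by hydroxy in place of hydrogen on an aromatic carbon. Going by the values given here, the only measured step that bears on this change is the one where a methoxy entered an aromatic carbon, a 7.6-fold lower number from compound 2 to compound 3 (0.88 log units; beyond the scatter), and a hydroxy entering an aromatic carbon is a different group; a step in the same direction but of smaller size is expected. For compound 4 a lower number in this assay is expected, a 2.6-fold lower number from compound 2 to compound 4 (0.41 log units; beyond the scatter), giving an estimate of 20 ug/mL with a range of 8 ug/mL to 50 ug/mL.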

Compound 4, half-maximal inhibitory concentration: 13.1 ug/mL
Compound 4: middle estimate off by 1.5-fold (0.18 log units), on the high side, and the stated range covers the measured number.
By their numbers in this assay, from the lowest: compounds 3 and 4 (each within the scatter of the next); then compounds 1 and 2 (each within the scatter of the next).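

In this assay the change from 3-methoxyphenyl to 4-hydroxy-3-methoxyphenyl gives a 3.9-fold lower number from compound 2 to compound 4 (0.59 log units; beyond the scatter) and shows that a hydroxy ortho to the methoxy group also lowers the number. With a 7.6-fold lower number from compound 2 to compound 3 (0.88 log units; beyond the scatter) as the other step, two different oxygen-bearing additions to this ring of compound 2 now lower the number, so the earlier methoxy result no longer stands alone. Nothing shown gives a cause for the step. Going by these compounds, whether a methoxy, an amine or a fluorine at this same place would match the hydroxy remains open. Also open, on these data alone, is whether the hydroxy step holds with the nitro group placed as in compound 1.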